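This account rests on a few compounds, and the source may have more. Where it says the series, first, only, none or still open, it means among the compounds named here.

Compound 1 `COCCOc1cc(/C=C/c2ccc3ccccc3c2)ccc1OC`: 2990 nM
Compound 2 `COCCOc1cc(/C=C\c2ccc3ccccc3c2)ccc1OC`: 2990 nM
Compound 3 `Cc1ccc(/C=C\c2ccc3ccccc3c2)cc1`: > 5000 nM (a limit)

In a functional assay on A549 cells (Homo sapiens) for inhibition (on this read-out higher numbers stand for weaker inhibition and lower numbers for stronger inhibition), compound 1 gives 2990 nM, level with compound 2 at 2990 nM. The value for compound 3 is a limit, > 5000 nM.

Compound 4 `COc1ccc(/C=C/c2ccc3ccccc3c2)cc1[N+](=O)[O-]` departs from compound 1 by nitro in place of 2-methoxyethoxy on an aromatic carbon, ortho to a methoxy group. Among the compounds with values here, the one measured step, no change at the digits printed from compound 1 to compound 2 (within the scatter), reflects the fact that compounds 1 and 2 differ only in the configuration as drawn and leaves this position untouched, so it sets no size for the swap. No shift beyond the scatter is therefore expected in this assay, in either direction, though with wide uncertainty. The expected change is a 1.2-fold lower number from compound 1 to compound 4 (0.08 log units; within the scatter). For compound 4 the estimated value is 2500 nM, with an expected range of 600 nM to 5000 nM.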

Compound 4, half-maximal inhibitory concentration: > 5000 nM
Compound 4: a limit, no number; the forecaster's own chance of this, stated with the estimate: 35%; at least 2.0-fold (0.30 log units) between middle value and limit.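

In this assay, within the data shown here, nitro in place of 2-methoxyethoxy on an aromatic carbon, ortho to a methoxy group, gives an at least 1.6-fold higher number from compound 1 to compound 4 (0.22 log units; that floor lies within the scatter), the first reading on this position. Compound 4 gives > 5000 nM, which is a limit and not a number, so only a floor is known: the limit of > 5000 nM in this assay, at which 2 of the 4 values shown sit. The earlier step could not speak to this position: the fact that compounds 1 and 2 differ only in the configuration as drawn.

From the compounds shown here alone, whether the true size of this swap lies beyond the scatter stays open. So does how an amine or a carboxylic acid on this aromatic carbon would read.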